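A few compounds are considered here, and "the series" means these few. Any claim that something is new, unique, unknown or untested is made for them only; others in the source may bear on it.

Compound 1 `FC(F)(F)Oc1cccc(Nc2nnnc3ccc(N4CCNCC4)nc23)c1`: 11500 nM
Compound 2 `CCN1CCN(c2ccc3nnnc(Nc4cccc(OC(F)(F)F)c4)c3n2)CC1`: 16900 nM

In a functional assay on PC-3 cells (Homo sapiens) for antiproliferative activity, read by MTT assay, with a stated time of 96 h (a higher number here means a weaker inhibitor, a lower number a stronger inhibitor), compound 2 gives 16900 nM, and compound 1, at 11500 nM, lies within the scatter of it, so the two cannot be told apart. Compound 3 `FC(F)(F)Oc1cccc(Nc2nnnc3ccc(N4CCCC4)nc23)c1` has not yet been measured. It carries pyrrolidin-1-yl in place of 4-ethylpiperazin-1-yl on an aromatic carbon. Among the compounds with values here, one measured step bears on this position, ethyl in place of hydrogen on an amine nitrogen in a ring, and it is small: a 1.5-fold higher number from compound 1 to compound 2 (0.17 log units; within the scatter). That step keeps the six-membered ring, whereas this change replaces it, so the data cover the exchange only indirectly. With so little to go on, no shift beyond the scatter is expected in this assay, in either direction. The expected step is a 1.4-fold lower number from compound 2 to compound 3 (0.15 log units; within the scatter). For compound 3 the estimated value is 12000 nM, with an expected range from 4000 nM to 35000 nM.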

Compound 3, half-maximal inhibitory concentration: > 100000 nM
Compound 3 was reported as a limit (the forecaster's own chance of this, stated with the estimate: 10%); middle value at least 8.3-fold (0.92 log units) away from the limit.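

Replacing the six-membered ring on this aromatic carbon with pyrrolidin-1-yl gives an at least 5.9-fold higher number from compound 2 to compound 3 (0.77 log units; beyond the scatter), and the same exchange starting from piperazin-1-yl gives an at least 8.6-fold higher number from compound 1 to compound 3 (0.93 log units; beyond the scatter). Within the data shown here, the position is therefore not indifferent to the group it carries in this assay: the earlier compounds differed only by ethyl in place of hydrogen on an amine nitrogen in a ring and stayed within the scatter of each other, whereas exchanging the ring itself moves the number beyond it. The figure for compound 3 is a limit of the assay and not a number: the limit of > 100000 nM in this assay, at which 1 of the 3 values shown sits.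

The compounds shown leave open whether this step goes with the ring size or with the ring's second nitrogen, as pyrrolidin-1-yl differs from both six-membered groups in both. A piperidin-1-yl or morpholin-4-yl group at this position would separate the two.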